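The compounds below may be only part of what the source reports. "The series", "measured", "known", "first", "only" and "open" are said of these compounds alone.

Three measured compounds share one core. Compound 1 `COCc1cc(CN2CCCC2)c(O)c2ncccc12` gives 1350 nM in a functional assay on MES-SA/Dx5 cells (Homo sapiens) for inhibition, with a stated time of 72 h; a higher number here means a weaker inhibitor, a lower number a stronger inhibitor. Compound 2 `CCOCc1cc(CN2CCCC2)c(O)c2ncccc12` gives 912 nM in this assay, and compound 3 `CCOCc1cc(CN2CCCCC2)c(O)c2ncccc12` gives 776 nM. The change from compound 1 to compound 2 is methyl in place of hydrogen on a saturated chain carbon bound to an oxygen on a saturated carbon, giving a 1.5-fold lower number from compound 1 to compound 2 (0.17 log units; within the scatter). The change to compound 3 gives a 1.2-fold lower number from compound 2 to compound 3 (0.07 log units; within the scatter). The difference between the cores of compound 1 and compound 3 is not broken down here. Compound 4 `CCCOCc1cc(CN2CCCCC2)c(O)c2ncccc12` is not yet measured; it differs from compound 3 by methyl in place of hydrogen on a saturated chain carbon, two bonds along the chain from an oxygen on a saturated carbon, the same kind of change as from compound 1 to compound 2, though here the place lies two bonds along the chain from the oxygen rather than bound to it. A step of similar small size is expected, a 1.2-fold lower number from compound 3 to compound 4 (0.08 log units; within the scatter), because a 1.5-fold lower number from compound 1 to compound 2 (0.17 log units; within the scatter) was small. Compound 4 is therefore estimated at 650 nM, between 350 nM and 1200 nM.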

Compound 4, half-maximal inhibitory concentration: 339 nM
Compound 4: the middle estimate sits 1.9-fold (0.28 log units) above what was measured; the measured number lies below the stated range.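

In this assay, the ethoxy to propoxy change gives a 2.3-fold lower number from compound 3 to compound 4 (0.36 log units; beyond the scatter). Set beside the earlier methyl in place of hydrogen on the chain, the two steps do not differ by more than repeated measurements would: the same change on two cores in this assay, a 1.5-fold lower number (0.17 log units; within the scatter) from compound 1 to compound 2 and a 2.3-fold lower number (0.36 log units; beyond the scatter) from compound 3 to compound 4, 1.5-fold (0.19 log units) apart, within the scatter of two such steps. This fits a single small effect on both cores, but only the newer step lies beyond the scatter, the methyl enters at a different place along the chain in each pair, and two pairs cannot show that the effect holds on other cores.

The compounds shown leave open whether a longer chain than propoxy, or a branched chain, would lower the number further. They also leave open what an amine at the end of the chain would do.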